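Phenyl for Methyl: an Expected Toxicity Reading

The source may report more compounds than this note shows. Statements on the series, on what has been measured and on what is new or still open speak of the compounds shown alone.

Measured compounds:
compound 1, `CCCC(=O)N/N=C1\C[C@H]2CC[C@]1(C)C2(C)C`, > 1190000 nM
compound 2, `CC(=O)N/N=C1\C[C@H]2CC[C@]1(C)C2(C)C`, "not determined" (no result reported)

In an ADME assay on MDCK cells (Canis lupus familiaris) for cytotoxicity, read by MTT assay, with a stated time of 48 h (on this read-out higher numbers stand for lower toxicity in this test and lower numbers for higher toxicity in this test), compound 1 gives > 1190000 nM, which is a limit of the test and not a number. For the measured compounds named here, compound 2 has no reading in this assay at all, so it cannot be placed on any scale; the only other value shown is the limit (the limit of > 1190000 nM in this assay, at which 1 of the 2 values shown sits), which belongs to compound 1. The unmeasured compound 3, `CC1(C)[C@@H]2CC[C@@]1(C)/C(=N/NC(=O)c1ccccc1)C2`, differs from compound 2 by phenyl in place of methyl on a carbonyl carbon. Going by the values given here, no measured pair of neighbours shows what such a swap does here, so no step size can be read off; the expectation rests only on the fact that the one reading sits at the limit. Compound 3 is expected, in this assay, to give roughly 600000 nM, with a plausible range from 100000 nM to 2000000 nM, and a fair chance that the result is again reported only as a limit.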

Compound 3, half-maximal cytotoxic concentration: > 1040000 nM
Compound 3: only a limit was reported; the forecaster's own chance of this, stated with the estimate: 45%; at least 1.7-fold (0.23 log units) between middle value and limit.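

In this assay compound 3 gives > 1040000 nM as a limit of the test, not a number. For the compounds shown here, compound 1 gives > 1190000 nM as a limit too, so no step from compound 1 to compound 3 can be read. Going by these compounds alone, still open is whether swapping the one group for the other alters the reading at all.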